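The source may report more compounds than this note shows. Statements on the series, on what has been measured and on what is new or still open speak of the compounds shown alone.

Measured in a functional assay on ECa-109 cells (Homo sapiens) for cytotoxicity, read by MTT assay, with a stated time of 48 h; on this read-out higher numbers stand for weaker inhibition and lower numbers for stronger inhibition:
Compound 1 `COc1cc(-n2c(-c3ccc(Br)cc3)cn(C(C)=O)c2=O)cc(OC)c1OC`: 3800 nM
Compound 2 `COc1cc(-n2c(-c3ccc(Cl)cc3)cn(C(C)=O)c2=O)cc(OC)c1OC`: > 50000 nM (a limit)
Compound 3 `COc1ccc(-c2cn(C(C)=O)c(=O)n2-c2cc(OC)c(OC)c(OC)c2)cc1`: > 50000 nM (a limit)

Compound 3 reads > 50000 nM, which is a limit of the assay and not a number. Within the data shown here, the series so far sits largely at one reading: the limit of > 50000 nM in this assay, at which 2 of the 3 values shown sit. Only compound 1 gives a true number.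

Compound 4 `COc1cc(-n2c(-c3ccc(F)cc3F)cn(C(C)=O)c2=O)cc(OC)c1OC` differs from compound 3 at one place: 2,4-difluorophenyl in place of 4-methoxyphenyl on an aromatic carbon. Two measured steps at this same aromatic ring bear on the change, an at least 13-fold higher number from compound 1 to compound 3 (1.11 log units; beyond the scatter) and an at least 13-fold higher number from compound 1 to compound 2 (1.11 log units; beyond the scatter), and both are large. Among the measured compounds shown here, no compound with fluorine has been measured, so the guide is indirect. Compound 2 also carries a halogen, yet it reads > 50000 nM, again a limit. A halogen alone therefore does not promise a measurable number, and only a small shift towards stronger inhibition, or none, is expected in this assay. The expected change is an at least 1.2-fold lower number from compound 3 to compound 4 (0.09 log units; that floor lies within the scatter). Compound 4 is estimated at 40000 nM, within an expected range of 8000 nM to 80000 nM.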

Compound 4, half-maximal inhibitory concentration: > 50000 nM
Compound 4: a limit, no number; the forecaster's own chance of this, stated with the estimate: 60%; middle value at least 1.2-fold (0.09 log units) from the limit.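

Putting 2,4-difluorophenyl in place of 4-methoxyphenyl at this position leaves the reading in this assay at a limit of the assay, so this fluorine pattern does not restore a true number. Among these compounds, the one readable step is an at least 13-fold higher number from compound 1 to compound 4 (1.11 log units; beyond the scatter), while the steps from compound 2 and from compound 3 to compound 4 set one limit against another and cannot be read. Compound 1, with its 4-bromophenyl group, remains the only compound with a true number, and the others gather at one reading: the limit of > 50000 nM in this assay, at which 3 of the 4 values shown sit.

Going by these compounds, whether that true number is special to the 4-bromophenyl group stays open, and a 4-iodophenyl group or a phenyl ring carrying an amine at this place would test it. The limits also give no order among compound 2, compound 3 and compound 4.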